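Nitro Added to a Chlorophenyl Sulfonamide: Cytotoxicity Expectation

The source may report more compounds than this note shows. Statements on the series, on what has been measured and on what is new or still open speak of the compounds shown alone.

Measured so far:
compound 1 `O=S(=O)(Nc1ccc2oc(-c3ccccc3)nc2c1)c1ccc(Cl)cc1` gives 65000 nM
compound 2 `COc1ccccc1S(=O)(=O)Nc1ccc2oc(-c3ccccc3)nc2c1` gives 41000 nM

Two sulfonamides sharing the same core have been tested in an ADME assay on HEK293 cells (Homo sapiens) for cytotoxicity, read by resazurin assay, with a stated time of 48 h; on this read-out lower numbers stand for higher toxicity in this test and higher numbers for lower toxicity in this test. In this assay compound 1 gives 65000 nM, the higher of the two numbers, and compound 2 gives 41000 nM. Among the compounds with values here, the only step between them, a 1.6-fold lower number from compound 1 to compound 2 (0.20 log units; within the scatter), exchanges the whole aryl group on the sulfonyl sulfur, and that exchange does not move the read-out beyond the scatter.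

Compound 3 `O=[N+]([O-])c1cc(S(=O)(=O)Nc2ccc3oc(-c4ccccc4)nc3c2)ccc1Cl` has not yet been measured. Its change from compound 1 is nitro in place of hydrogen on an aromatic carbon, the nitro sitting ortho to the chloro group and meta to a large group. Within the data shown here, no measured step touches this position, so the expectation rests only on the observation that a larger swap of the aryl group left the number within the scatter. On that basis compound 3 is estimated at 55000 nM, with a range from 20000 nM to 150000 nM, which means an expected step of a 1.2-fold lower number from compound 1 to compound 3 (0.07 log units; within the scatter), not beyond the scatter.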

Compound 3, half-maximal cytotoxic concentration: 90000 nM
Estimate against measurement, compound 3: 1.6-fold (0.21 log units) below, within the range that was stated.
By their numbers in this assay, from the lowest: compounds 2, 1 and 3 (each within the scatter of the next, the first and the last beyond it).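

In this assay the addition of nitro in place of hydrogen gives a 1.4-fold higher number from compound 1 to compound 3 (0.14 log units; within the scatter) and so leaves the read-out within the scatter. Within the data shown here, this is the first measured change at this position, ortho to a chloro group and meta to a large group, whereas the earlier step exchanged the whole aryl group on the sulfonyl sulfur. The result shows that this aromatic carbon of compound 1 can carry a nitro group with no change beyond the scatter in this test, although no evidence is available that would explain this outcome.

The single substitution leaves open whether an amine, a carboxylic acid or a methoxy group at the same position would also stay within the scatter in this assay. It also leaves open whether the nitro group would give a similar result on an aryl group without the chloro group, or with a bromo group in its place, since all of the compounds shown share one core and only compound 1 and compound 3 differ at this position.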